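Methyl to Methoxy on a Cytotoxicity-Silent Core

The compounds below may be only part of what the source reports. "The series", "measured", "known", "first", "only" and "open" are said of these compounds alone.

Compound 3 `Cc1ccc2[nH]c(=O)c(-c3nc4ccccc4[nH]3)cc2c1` was tested in an ADME assay on L02 cells (Homo sapiens) for cytotoxicity, read by MTT assay, with a stated time of 48 h; a lower number here means a stronger inhibitor, a higher number a weaker inhibitor. In this assay compound 3 gives only a limit, > 100000 nM. Compound 1 `COc1ccc2[nH]c(=O)c(-c3nc4cc(F)ccc4[nH]3)cc2c1` likewise reaches only the limit > 100000 nM in this assay. Compound 2 `COc1ccc2[nH]c(=O)c(-c3nc4cc(Cl)ccc4[nH]3)cc2c1` also stops at the limit > 100000 nM. Among the compounds with values here, the one step with a single change, a step that the two limits leave unreadable from compound 1 to compound 2, therefore cannot be read. Within the data shown here, every value so far sits at the limit of > 100000 nM in this assay, at which 3 of the 3 values shown sit. Compound 4 `COc1ccc2[nH]c(=O)c(-c3nc4ccccc4[nH]3)cc2c1` differs from compound 3 by methoxy in place of methyl on an aromatic carbon. Among the measured compounds shown here, no measured step bears on a methoxy in place of a methyl, and the data give no number to move from. Compound 4 is therefore expected to remain at the limit, estimated at 200000 nM with a range of 100000 nM to 1000000 nM, a step that the limit leaves unreadable from compound 3 to compound 4 that is expected to mean no change beyond the scatter.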

Compound 4, half-maximal inhibitory concentration: > 100000 nM
Compound 4: only a limit was reported; the forecaster's own chance of this, stated with the estimate: 90%; the middle value is on the limit's open side.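

Compound 4 gives only a limit in this assay, > 100000 nM. The steps from compound 1, compound 2 and compound 3 to compound 4 therefore cannot be read: the limit of > 100000 nM in this assay, at which 4 of the 4 values shown sit. The compounds shown leave open how far any of them lies past that limit.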